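Benzylamino in place of morpholin-4-yl on a carbonyl carbon

This account rests on a few compounds, and the source may have more. Where it says the series, first, only, none or still open, it means among the compounds named here.

In a functional assay on MCF7 cells (Homo sapiens) for antiproliferative activity, read by MTT assay, with a stated time of 24 h (a lower number here means a stronger inhibitor, a higher number a weaker inhibitor), compound 1 `CCCCc1oc2ccccc2c1C(=O)c1ccc(OCCCC(=O)N2CCCCC2)cc1` gives 33000 nM and compound 2 `CCCCc1oc2ccccc2c1C(=O)c1ccc(OCCCC(=O)N2CCOCC2)cc1` gives 41200 nM. Among the measured compounds shown here, these are the only two numbers so far, and they lie within the scatter of each other, so compound 2 stands level with compound 1. Compound 3 `CCCCc1oc2ccccc2c1C(=O)c1ccc(OCCCC(=O)NCc2ccccc2)cc1` keeps the shared core and changes the same place, with benzylamino in place of morpholin-4-yl on a carbonyl carbon. For the measured compounds named here, the only measured step at this place is a 1.2-fold higher number from compound 1 to compound 2 (0.10 log units; within the scatter), which swapped morpholin-4-yl for piperidin-1-yl. Going by the values given here, it is a thin guide, since no measured compound yet carries an aromatic ring of carbon only here. No step beyond the scatter is therefore expected, and the estimated step is a 1.4-fold lower number from compound 2 to compound 3 (0.14 log units; within the scatter). In this assay, compound 3 is expected at 30000 nM, within an estimated range of 10000 nM to 80000 nM.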

Compound 3, half-maximal inhibitory concentration: 49700 nM
Beside the measured number, compound 3's estimate is 1.7-fold (0.22 log units) below it, and the stated range covers the measured number.
By their numbers in this assay, from the lowest: compounds 1, 2 and 3 (each within the scatter of the next).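

Benzylamino puts an aromatic ring of carbon only and a hydrogen-bond donor on this carbonyl carbon, and morpholin-4-yl has neither, yet this assay shows a 1.2-fold higher number from compound 2 to compound 3 (0.08 log units; within the scatter) for this change and a 1.5-fold higher number from compound 1 to compound 3 (0.18 log units; within the scatter) for benzylamino in place of piperidin-1-yl on the same carbon. The three groups shown at this place therefore cannot be told apart in this assay, even though one of them is not a saturated ring and carries the amide hydrogen. No measurement is at hand that would explain this level result.

Going by these compounds, whether any group on this carbonyl carbon can move the number beyond the scatter remains open. A carboxylic acid at this place, a piperazine ring, or a longer chain in the benzylamino group are all outside the compounds shown.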